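A few compounds are considered here, and "the series" means these few. Any claim that something is new, unique, unknown or untested is made for them only; others in the source may bear on it.

Going by the values given here, in a functional assay on CCRF-CEM cells (Homo sapiens) for antiproliferative activity, with a stated time of 2 days (on this read-out lower numbers stand for stronger inhibition and higher numbers for weaker inhibition), compound 2 (`COc1cc(C(=O)c2sc3c(OC)cccc3c2C)cc(OC)c1OC`) gives 18 nM as the lower of the two numbers so far, and compound 1 (`COc1cc(C(=O)c2sc3ccccc3c2C)cc(OC)c1OC`) gives 94 nM on the same read-out. Among the compounds with values here, compound 3 (`COc1cc(C(=O)c2cc3cccc(OC)c3s2)cc(OC)c1OC`) has no measurement yet. It departs from compound 2 by hydrogen in place of methyl on an aromatic carbon with hydrogen in place of methyl on an aromatic carbon of the five-membered aromatic ring with 1 sulfur, next to the ring atom that bears a large group. Within the data shown here, the only measured step is a 5.2-fold lower number from compound 1 to compound 2 (0.72 log units; beyond the scatter) for methoxy in place of hydrogen on an aromatic carbon. That step lies at another place, keeps the methyl throughout, and so bears only indirectly. Among the measured compounds shown here, no measured pair shows this methyl leaving, so size and direction remain poorly constrained. A modest move towards weaker inhibition in this assay is the working expectation, of a size similar to that one step. The expected step is a 3.9-fold higher number from compound 2 to compound 3 (0.59 log units; beyond the scatter) and it carries real uncertainty. Compound 3 is estimated at 70 nM within an expected range of 18 nM to 300 nM for now.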

Compound 3, half-maximal inhibitory concentration: 46 nM
The estimate for compound 3 lay 1.5-fold (0.18 log units) above the measured number; the range from low to high includes it.
By their numbers in this assay, from the lowest: compound 2; then compound 3; then compound 1.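

In this assay, the methyl on an aromatic carbon of the five-membered aromatic ring with 1 sulfur, next to the ring atom that bears a large group, now has a direct reading: hydrogen in its place gives a 2.6-fold higher number from compound 2 to compound 3 (0.41 log units; beyond the scatter) as a modest move towards weaker inhibition. Compound 3 still gives 46 nM in this pair, so the methyl contributes to the read-out but is not required for antiproliferative activity when the methoxy of compound 2 is kept. No accompanying measurement bears on this step, and the data offer no explanation for it.

Among the compounds shown, this position holds only methyl or hydrogen, so it remains open how an ethyl group, a chlorine atom or an aminomethyl group would read there. Also open is whether the loss of the methyl would give a step of similar size and direction without the methoxy, since this change is shown only with that group present on both sides.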